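The compounds below may be only part of what the source reports. "The series", "measured", "known", "first", "only" and "open" are said of these compounds alone.

Measured so far in an assay on isolated protein for inhibition of serine/threonine-protein kinase TNNI3K (Homo sapiens); on this read-out lower numbers stand for stronger inhibition and higher numbers for weaker inhibition:
- compound 1, `CCc1cc(NC(=O)Nc2cccc(C(F)(F)F)c2)cc(Cl)c1Oc1cc(NC)ncn1`: <= 10 nM
- compound 2, `C[C@@H](O)CNc1cc(Oc2ccc(NC(=O)Nc3cccc(C(F)(F)F)c3)cc2)ncn1`: 63 nM
- compound 3, `CC(C)CNc1cc(Oc2ccc(NC(=O)Nc3cccc(C(F)(F)F)c3)cc2)ncn1`: 50 nM

Compound 1 gives only a limit of this assay, (the limit of <= 10 nM in this assay, at which 1 of the 3 values shown sits), not a number. Compounds 2 and 3 give numbers; the step of a 1.3-fold lower number from compound 2 to compound 3 (0.10 log units; within the scatter) changes the chain on the amino group and says nothing about the ring that carries the urea.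

Compound 4, `CNc1cc(Oc2ccc(NC(=O)Nc3cccc(C(F)(F)F)c3)cc2Cl)ncn1`, differs from compound 1 by hydrogen in place of ethyl on an aromatic carbon. For the measured compounds named here, no measured step touches this position, so no direct precedent exists for the size of the change. Compounds 2 and 3, which lack both the ethyl and the chloro group, sit well above the limit that compound 1 reaches.

For compound 4 the expectation is a modest loss, an at least 2.0-fold higher number from compound 1 to compound 4 (0.30 log units; that floor lies within the scatter), with a value of 20 nM and a range from 6 nM to 60 nM.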

Compound 4, half-maximal inhibitory concentration: 50 nM
For compound 4 the middle estimate is 2.5-fold (0.40 log units) below the measured one; the range from low to high includes it.
By their numbers in this assay, from the lowest: compounds 3, 4 and 2 (each within the scatter of the next). At a limit, below all of these: compound 1.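

In this assay, hydrogen in place of ethyl ortho to the (6-(methylamino)pyrimidin-4-yl)oxy group gives an at least 5.0-fold higher number from compound 1 to compound 4 (0.69 log units; beyond the scatter) and so makes this ring position the first site in the series with a step beyond the scatter. The earlier compounds shown here showed a change only in the chain on the amino group, and that step stayed within the scatter. Compound 1 gives a limit and not a number, so the full size of this step stays unknown: the limit of <= 10 nM in this assay, at which 1 of the 4 values shown sits.

On these data alone, whether a methyl group or a longer chain such as propyl at this position would match the ethyl group remains open. Also open, as far as these compounds go, is whether a methoxy group would be tolerated there.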